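A few compounds are considered here, and "the series" means these few. Any claim that something is new, unique, unknown or untested is made for them only; others in the source may bear on it.

Measured in an ADME assay on S9 fraction from liver (Mus musculus, strain ICR/CD-1) for metabolic stability, read by LC-MS, using NADPH, with a stated time of 5 min, tested at 2 uM; a higher number here means that the compound lasts longer, a lower number that the compound disappears faster:
- compound 1 `CCc1cc(Br)ccc1S(=O)(=O)N1CCC(N2CCC(C)CC2)CC1`: 0.152 h
- compound 2 `CC1CCN(C2CCN(S(=O)(=O)c3cccc(-c4ccccc4F)c3)CC2)CC1`: 0.283 h

Only these two numbers exist so far. Compound 2 at 0.283 h cannot be separated from compound 1 at 0.152 h, as the two values lie within the scatter of each other.

The next compound to be read is compound 3 `CC1CCN(C2CCN(S(=O)(=O)c3cccc(-c4ccc(Cl)cc4)c3)CC2)CC1`. It carries 4-chlorophenyl in place of 2-fluorophenyl on an aromatic carbon, meta to a large group (4-chlorophenyl in place of 2-fluorophenyl on an aromatic carbon). Among the measured compounds shown here, no step between measured compounds that differ in one place is available, so the data give no direct guide to this exchange. The only indication is indirect: compound 1 at 0.152 h and compound 2 at 0.283 h differ in more than one place, yet remain within the scatter of each other. On that basis, no step beyond the scatter is expected in this assay. The expected change is a 1.1-fold lower number from compound 2 to compound 3 (0.05 log units; within the scatter). The estimate for compound 3 is 0.25 h, with an expected range from 0.12 h to 0.5 h.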

Compound 3, half-life: 2.45 h
The estimate for compound 3 lay 9.8-fold (0.99 log units) below the measured number, and the stated range ends below it.
By their numbers in this assay, from the lowest: compounds 1 and 2 (each within the scatter of the next); then compound 3.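

In this assay, 4-chlorophenyl in place of 2-fluorophenyl, on an aromatic carbon meta to a large group, gives an 8.7-fold higher number from compound 2 to compound 3 (0.94 log units; beyond the scatter). Among the compounds shown here, this is the first step that can be read at a single place, and it shows that the number responds to the choice of aryl group at this position. The response appears even though the two groups have the same count of heavy atoms, the same type of ring, no hydrogen-bond donors or acceptors and no net charge, and no measurement at hand bears on what lies behind the step.

The exchange alters both the halogen and where it sits on the phenyl ring, so the compounds shown cannot say which of the two carries the step; 4-fluorophenyl and 2-chlorophenyl would separate them. As far as these compounds go, it also remains open whether the higher number depends on a halogen at all, or would persist with a nitrile or a methoxy group in the same place on the phenyl ring.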